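Working notes: 2,4-difluorophenyl to 2,5-difluorophenyl on a carbonyl carbon

A few compounds are considered here, and "the series" means these few. Any claim that something is new, unique, unknown or untested is made for them only; others in the source may bear on it.

- compound 1 `Cc1cccc(C(=O)N(C(=S)OCCN2C(=O)c3ccccc3C2=O)c2ccc(Cl)cc2)c1` gives 58000 nM
- compound 2 `O=C1c2ccccc2C(=O)N1CCOC(=S)N(C(=O)c1ccc(F)cc1F)c1ccc(Cl)cc1` gives 52000 nM

Both numbers come from an ADME assay on MT4 cells (Homo sapiens) for cytotoxicity, read by MTT assay (a higher number here means that more compound is tolerated, a lower number that less compound is tolerated), and compound 2 at 52000 nM sits within the scatter of compound 1. Compound 3 `O=C1c2ccccc2C(=O)N1CCOC(=S)N(C(=O)c1cc(F)ccc1F)c1ccc(Cl)cc1` is still unmeasured. The change from compound 2 is 2,5-difluorophenyl in place of 2,4-difluorophenyl on a carbonyl carbon and it amounts to 2,5-difluorophenyl in place of 2,4-difluorophenyl on a carbonyl carbon. Going by the values given here, the one measured step at that carbonyl carbon is a 1.1-fold lower number from compound 1 to compound 2 (0.05 log units; within the scatter) and it exchanged 3-methylphenyl for 2,4-difluorophenyl. Among the compounds with values here, no measured pair compares two difluorophenyl groups, so that step is only indirect evidence. On it, no shift beyond the scatter is expected in this assay for this swap. The estimated step is a 1.0-fold higher number from compound 2 to compound 3 (0.02 log units; within the scatter) and no real direction is expected. Compound 3 is estimated at 54000 nM (expected range 30000 nM to 95000 nM).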

Compound 3, half-maximal cytotoxic concentration: 54000 nM
Compound 3: the middle estimate sits on the measured number at the digits printed; the measured number falls inside the stated range.
By their numbers in this assay, from the lowest: compounds 2, 3 and 1 (each within the scatter of the next).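

In this assay, going by these compounds alone, 2,5-difluorophenyl in place of 2,4-difluorophenyl on the carbonyl carbon gives the first direct comparison of two difluorophenyl groups at this position, and it reads as a 1.0-fold higher number from compound 2 to compound 3 (0.02 log units; within the scatter) and so shows no real difference between the two. The second new comparison, with 3-methylphenyl, reads as a 1.1-fold lower number from compound 1 to compound 3 (0.03 log units; within the scatter) and so leaves all three groups at this carbonyl carbon within the scatter of each other in this assay for these compounds. No measured information is available to account for this flat reading.

The compounds shown leave open whether cyclohexyl, or a phenyl carrying an amine or a carboxylic acid, at this carbonyl carbon would move the number beyond the scatter. They also leave open whether a change elsewhere, such as a longer chain in the shared core, would do so.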